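Replacing a Chlorophenyl with an Amino-Methoxyphenyl Group

The source may report more compounds than this note shows. Statements on the series, on what has been measured and on what is new or still open speak of the compounds shown alone.

compound 1 `COc1ccc(CN(C(=O)CSc2nc3ccccc3s2)c2cc(OC)c(OC)c(OC)c2)cc1`: 426 nM
compound 2 `COc1ccc(CN(C(=O)CSc2nc3ccccc3s2)c2cc(OC)c(OC)c(OC)c2)cc1O`: 182 nM
compound 3 `COc1cc(N(Cc2ccc(Cl)cc2)C(=O)CSc2nc3ccccc3s2)cc(OC)c1OC`: 603000 nM

In a functional assay on HCT-116 cells (Homo sapiens) for antiproliferative activity, read by MTT assay, with a stated time of 48 h (on this read-out lower numbers stand for stronger inhibition and higher numbers for weaker inhibition), compound 3 stands highest of the three numbers measured, far from the others: a 1400-fold higher number from compound 1 to compound 3 (3.15 log units; beyond the scatter) and a 3300-fold higher number from compound 2 to compound 3 (3.52 log units; beyond the scatter). Compound 4 `COc1ccc(CN(C(=O)CSc2nc3ccccc3s2)c2cc(OC)c(OC)c(OC)c2)cc1N` differs from compound 3 by 3-amino-4-methoxyphenyl in place of 4-chlorophenyl on a saturated chain carbon bound to an amide-type nitrogen. Both measured steps that bear on this change are large and run toward weaker inhibition when the chloro-bearing ring arrives; compound 4 goes the other way, bringing back a methoxy-bearing ring resembling those of compound 1 and compound 2, with an amino group where compound 2 carries a hydroxy. A large step toward stronger inhibition is therefore expected, a 2000-fold lower number from compound 3 to compound 4 (3.30 log units; beyond the scatter). The estimate for compound 4 is 300 nM, within a range of 80 nM to 2500 nM.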

Compound 4, half-maximal inhibitory concentration: 491 nM
The estimate for compound 4 lay 1.6-fold (0.21 log units) below the measured number; the range from low to high includes it.
By their numbers in this assay, from the lowest: compound 2; then compounds 1 and 4 (each within the scatter of the next); then compound 3.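

In this assay, the amino-bearing ring recovers what the 4-chlorophenyl ring lost, with a 1200-fold lower number from compound 3 to compound 4 (3.09 log units; beyond the scatter). The amino group makes no clear difference compared with hydrogen on that carbon, with a 1.2-fold higher number from compound 1 to compound 4 (0.06 log units; within the scatter), but it does not match hydroxy, with a 2.7-fold higher number from compound 2 to compound 4 (0.43 log units; beyond the scatter), so the modest gain seen with hydroxy does not carry over to amino. Nothing available explains this difference between the groups. As far as these compounds go, it remains open whether a 4-fluorophenyl ring would perform as poorly as 4-chlorophenyl, and whether a methylamino or acetamido group would behave like amino.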